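Ester for Amide on a Bicyclic Nucleoside Sulfonate

The source may report more compounds than this note shows. Statements on the series, on what has been measured and on what is new or still open speak of the compounds shown alone.

Compound 1 `COC(=O)C(=O)CNC1=CS(=O)(=O)O[C@@]12[C@@H](CO[Si](C)(C)C(C)(C)C)O[C@@H](n1cc(C)c(=O)n(C)c1=O)[C@@H]2O[Si](C)(C)C(C)(C)C`, compound 2 `Cc1cn([C@@H]2O[C@H](CO[Si](C)(C)C(C)(C)C)[C@@]3(OS(=O)(=O)C=C3NCC(=O)C(N)=O)[C@H]2O[Si](C)(C)C(C)(C)C)c(=O)n(C)c1=O` and compound 3 `Cc1cn([C@@H]2O[C@H](CO[Si](C)(C)C(C)(C)C)[C@@]3(OS(=O)(=O)C=C3NCCC(N)=O)[C@H]2O[Si](C)(C)C(C)(C)C)c(=O)n(C)c1=O` were examined in a functional assay on HEL cells (Homo sapiens) for cytotoxicity, read by microscopy; a higher number here means that more compound is tolerated, a lower number that less compound is tolerated. For compound 1 the result is a limit of the assay, > 400000 nM. For compound 2 the result is likewise a limit, >= 16000 nM. For compound 3 the result is again a limit, >= 80000 nM. The core of compound 3 differs from that of compound 2 by carbamoylmethyl in place of carbamoylcarbonyl on a saturated chain carbon bound to an amine nitrogen. The change from compound 2 to compound 1 is methoxy in place of amino on a carbonyl carbon, and it gave a step that the two limits leave unreadable from compound 2 to compound 1. Compound 4 `COC(=O)CCNC1=CS(=O)(=O)O[C@@]12[C@@H](CO[Si](C)(C)C(C)(C)C)O[C@@H](n1cc(C)c(=O)n(C)c1=O)[C@@H]2O[Si](C)(C)C(C)(C)C` has not yet been measured. It differs from compound 3 by methoxy in place of amino on a carbonyl carbon; this is the same kind of change as from compound 2 to compound 1, though here the carbonyl carbon has a saturated chain carbon as its other neighbour rather than a carbonyl carbon. The earlier pair sits at the limit of >= 16000 nM in this assay, at which 1 of the 3 values shown sits, and (the limit of > 400000 nM in this assay, at which 1 of the 3 values shown sits), so no size for this kind of change can be read, and the expectation for compound 4 rests mainly on the limit of compound 3. A step that the limit leaves unreadable from compound 3 to compound 4 is expected in this assay. The estimate for compound 4 is 200000 nM, between 40000 nM and 800000 nM.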

Compound 4, minimum cytotoxic concentration: >= 400000 nM
Compound 4 gave a limit, no number; the forecaster's own chance of this, stated with the estimate: 80%; middle value at least 2.0-fold (0.30 log units) from the limit.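

In this assay compound 4 gives >= 400000 nM, which is a limit of the assay and not a number. Compound 1, compound 2 and compound 3 also stand at limits, and the steps from each of them to compound 4 cannot be read. The compounds shown leave open what size of step methoxy in place of amino on a carbonyl carbon gives in this assay.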